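The source may report more compounds than this note shows. Statements on the series, on what has been measured and on what is new or still open speak of the compounds shown alone.

For the measured compounds named here, compound 1 `CCCCNC(=O)NS(=O)(=O)c1ccc(-n2nc(C)cc2C)cc1` is the one compound with a number in a functional assay on the whole organism (blood, strain albino) with Mus musculus as the target, with stated times of 6 days and 4 h, at a dose of 0.4 mmol/kg by the oral route; on this read-out higher numbers stand for more inhibition at the one dose given (going by the name of the read-out) and lower numbers for less inhibition; there compound 1 gives 2%. Compound 2 `Cc1cc(C)n(-c2ccc(S(=O)(=O)NC(=O)NCc3ccccc3)cc2)n1` returns only a limit of this assay, < 1%. The step from compound 1 to compound 2 was a number at least 1 percentage points lower from compound 1 to compound 2 (that floor lies within the scatter), and with the limit of < 1% in this assay, at which 1 of the 2 values shown sits, it shows how little room lies below compound 1. Going by the values given here, compound 3 `CCCCNC(=S)NS(=O)(=O)c1ccc(-n2nc(C)cc2C)cc1` differs from compound 1 by a group of 7 heavy atoms (5 carbon, 1 nitrogen, 1 sulfur; no ring) in place of a group of 7 heavy atoms (5 carbon, 1 nitrogen, 1 oxygen; no ring), on a sulfonamide nitrogen No measured step touches this change, so no shift beyond the scatter is expected in this assay. Compound 3 is therefore estimated at 2%, ranging from 0% to 12%, an expected step of no change at the digits printed from compound 1 to compound 3 (within the scatter).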

Compound 3, a percentage reported as inhibition, in the whole organism at one dose (the size of the read-out at that dose, not a potency): 1%
The estimate for compound 3 lay 1 percentage points above the measured number; the measured number falls inside the stated range.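

In this assay, the exchange of oxygen for sulfur in the butylcarbamoyl group on the sulfonamide nitrogen gave a number 1 percentage points lower from compound 1 to compound 3 (within the scatter). This adds a second kind of change at this end of the molecule, and like the earlier one it does not lift the read-out clear of the scatter. Little can be read from this step because the values lie so close to the bottom of the scale: the limit of < 1% in this assay, at which 1 of the 3 values shown sits.

As far as these compounds go, whether any change here can raise the inhibition stays open. A cyclohexyl group in place of the butyl chain, or a carboxylic acid at its end, would address that question.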